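Isopropyl for methyl: metabolic stability notes on the series

The source may hold more compounds than are shown below. What is called first, only, known or untested is meant among the compounds shown, and "the series" means these compounds.

Measured in an ADME assay (liver, Mus musculus) for metabolic stability, read by LC-MS, using microsomes, tested at 1 uM; on this read-out lower numbers stand for a shorter-lived compound and higher numbers for a longer-lived compound:
compound 1 `C/C(=N/c1ccnc2cc(Cl)ccc12)NC1CCN(Cc2ccccc2)CC1`, a limit of the assay, > 1 h
compound 2 `CCN(CC)CCCCN/C(=N\c1ccnc2cc(Cl)ccc12)C(C)C`, 0.7 h
compound 3 `CCN(CC)CCCCN/C(C)=N\c1ccnc2cc(Cl)ccc12`, a limit of the assay, > 1 h

Going by the values given here, two of the three measured compounds give only a limit, namely (the limit of > 1 h in this assay, at which 2 of the 3 values shown sit), so the one counted step starts from a limit and is itself only a floor. That step is isopropyl in place of methyl on a carbon with a double bond to nitrogen and gives an at least 1.4-fold lower number from compound 3 to compound 2 (0.15 log units; that floor lies within the scatter). Compound 2 alone returns a number in this assay; compound 1 and compound 3 do not, and how far either sits past the limit is not known.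

Compound 4 `CC(C)/C(=N/c1ccnc2cc(Cl)ccc12)NC1CCN(Cc2ccccc2)CC1` is not yet measured. It differs from compound 1 by isopropyl in place of methyl on a carbon with a double bond to nitrogen, the same change as from compound 3 to compound 2, on the same kind of carbon with the same neighbours. The difference between the core of compound 1 and the core of compound 3 is not broken down here.

For compound 4 the expectation is a step of an at least 1.2-fold lower number from compound 1 to compound 4 (0.09 log units; that floor lies within the scatter) in this assay, resting on an at least 1.4-fold lower number from compound 3 to compound 2 (0.15 log units; that floor lies within the scatter) and on compound 1 sitting at > 1 h, a limit from which the size of any drop cannot be fixed. Compound 4 is thus estimated at 0.8 h, within a range from 0.4 h to 1.6 h, with a fair chance that this assay again returns only a limit.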

Compound 4, half-life: 0.5 h
The estimate for compound 4 lay 1.6-fold (0.20 log units) above the measured number; the measured number falls inside the stated range.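

In this assay, isopropyl in place of methyl on a carbon with a double bond to nitrogen can now be read on a second core, giving an at least 2.0-fold lower number from compound 1 to compound 4 (0.30 log units; that floor lies within the scatter). Each step starts from a limit of the assay, so each size is only a floor, and both floors lie within the scatter; the two cores therefore show a compatible reading, not an established drop of a known size: the same change on two cores in this assay, an at least 1.4-fold lower number (0.15 log units; that floor lies within the scatter) from compound 3 to compound 2 and an at least 2.0-fold lower number (0.30 log units; that floor lies within the scatter) from compound 1 to compound 4; the limit leaves it open whether they differ Neither step shows how large the change is, or whether the core alters its size, and carrying the change from one core to the other cannot be called quantitative because the methyl compounds give no number: the limit of > 1 h in this assay, at which 2 of the 4 values shown sit.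

The compounds shown leave open how far the two methyl compounds lie past the limit in this assay, and with that the true size of both steps. Also open, going by these compounds, is how this carbon behaves with other groups on it, such as ethyl or tert-butyl, where a pair that returns numbers on both sides on the core of compound 1 and the core of compound 3 would allow the steps to be compared directly.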